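From 3-chlorophenyl to 2,5-dimethylphenyl on a sulfur

The compounds below may be only part of what the source reports. "The series", "measured", "known", "first", "only" and "open" are said of these compounds alone.

In a functional assay on A549 cells (Homo sapiens) for antiproliferative activity, read by MTT assay, with a stated time of 72 h (a lower number here means a stronger inhibitor, a higher number a weaker inhibitor), compound 1 `Cc1ccc(SC(=S)N2CCN(C(=O)OC(C)(C)C)CC2)cc1` gives 2110 nM, compound 2 `CC(C)(C)OC(=O)N1CCN(C(=S)Sc2ccc(Cl)cc2)CC1` gives 1070 nM, and compound 3 `CC(C)(C)OC(=O)N1CCN(C(=S)Sc2cccc(Cl)c2)CC1` gives 634 nM. The standing of the last of these rests on two comparisons: a 1.7-fold lower number from compound 2 to compound 3 (0.23 log units; within the scatter), and a 3.3-fold lower number from compound 1 to compound 3 (0.52 log units; beyond the scatter).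

Compound 4 `Cc1ccc(C)c(SC(=S)N2CCN(C(=O)OC(C)(C)C)CC2)c1` carries a new group: 2,5-dimethylphenyl in place of 3-chlorophenyl on a sulfur. For the measured compounds named here, no measured compound has this group, so the nearest guides are the two steps away from the methyl-bearing ring of compound 1. Those are a 2.0-fold lower number from compound 1 to compound 2 (0.29 log units; within the scatter), and the larger step already given. Returning to methyl groups should therefore raise the number in this assay modestly. The expected change is a 2.2-fold higher number from compound 3 to compound 4 (0.34 log units; beyond the scatter). For compound 4 the estimate is 1400 nM, with an expected range of 550 nM to 3500 nM.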

Compound 4, half-maximal inhibitory concentration: 539 nM
Estimate against measurement, compound 4: 2.6-fold (0.41 log units) above, and the stated range ends above it.
By their numbers in this assay, from the lowest: compounds 4, 3, 2 and 1 (each within the scatter of the next, the first and the last beyond it).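

In this assay changing the ring on the sulfur gives a 1.2-fold lower number from compound 3 to compound 4 (0.07 log units; within the scatter) and a 2.0-fold lower number from compound 2 to compound 4 (0.30 log units; within the scatter) so a ring with two methyl groups and no chlorine sits level with both chlorine-bearing rings. Against the 4-methylphenyl ring there is a 3.9-fold lower number from compound 1 to compound 4 (0.59 log units; beyond the scatter) so methyl groups on this ring do not by themselves bring the higher number of compound 1. Nothing measured here gives a reason for these steps. On these data alone, what an amine or a carboxylic acid on this ring would do stays open, as does any change to the rest of the shared core.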